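A few compounds are considered here, and "the series" means these few. Any claim that something is new, unique, unknown or untested is made for them only; others in the source may bear on it.

Working notes on the amide series.

In an assay for inhibition of acyl-CoA:cholesterol acyltransferase (Oryctolagus cuniculus), using microsomes (on this read-out lower numbers stand for stronger inhibition and higher numbers for weaker inhibition), compound 1, `CCCCCCCCCCCCCCCC(=O)Nc1cccc2c1OC(C)(C)C2`, gives 890 nM. Compound 2, `CCCCCCCCCCC1(C(=O)Nc2cccc3c2OC(C)(C)C3)CCCC1`, gives 500 nM in this assay. Going by the values given here, compound 3, `CCCCCCCCC(C)(C)C(=O)Nc1c(C)cc(C)c2c1OC(C)(C)C2`, gives 140 nM in this assay; that is the lowest of the three numbers, and its separation from both compound 2 and compound 1 lies beyond the usual scatter of repeated measurements, so compound 3 stands as the strongest inhibitor among the compounds measured so far.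

Compound 4, `Cc1cc(C)c(NC(=O)C(C)(C)CCCc2ccc(CC(C)C)cc2)c2c1CC(C)(C)O2`, keeps the substituted core and the branched amide of compound 3 and changes only the tail: 4-isobutylphenyl in place of pentyl on a saturated chain carbon, four bonds along the chain from a carbonyl carbon. Among the compounds with values here, no pair of measured compounds differs in just this way, so the size of the step is an open question. The two measured tails, straight in compound 1 and ring-bearing in compound 2, frame an aryl-terminated tail without reaching it.

The expectation for compound 4 in this assay is a step from compound 3 that stays within the scatter, a 1.4-fold lower number from compound 3 to compound 4 (0.15 log units; within the scatter), or at most a modest gain. Compound 4 is estimated at 100 nM, with a range of 30 nM to 400 nM.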

Compound 4, half-maximal inhibitory concentration: 40 nM
Estimate against measurement, compound 4: 2.5-fold (0.40 log units) above, within the range that was stated.
By their numbers in this assay, from the lowest: compound 4; then compound 3; then compounds 2 and 1 (each within the scatter of the next).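

With the core and the branched amide held fixed, 4-isobutylphenyl in place of pentyl on a saturated chain carbon, four bonds along the chain from a carbonyl carbon, gives a 3.5-fold lower number from compound 3 to compound 4 (0.54 log units; beyond the scatter) in this assay as the read-out. This only single-place step in the series shows that this position accepts an aromatic ring and that the change in the tail alone moves the number beyond the scatter. Nothing measured here bears on why the number falls.

The compounds shown leave open whether the lower number belongs to the phenyl ring, to the isobutyl group on it or simply to the larger tail. A plain phenyl, a cyclohexyl or a 4-carboxyphenyl group at the same place would help separate these readings.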